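The source may hold more compounds than are shown below. What is called first, only, known or untested is meant among the compounds shown, and "the series" means these compounds.

Measured in an in vivo ADME assay on the whole organism (strain 129/SvEvBrd x C57BL/6) for pharmacokinetics, with Mus musculus as the target; a higher number here means that a larger share of the oral dose reaches the circulation, a lower number that a smaller share of the oral dose reaches the circulation:
Compound 1 `CC(=O)c1cccc([C@@H](O)[C@H](O)[C@H](O)CO)n1`: 88%
Compound 2 `CC(=O)c1nc([C@@H](O)[C@H](O)[C@H](O)CO)c(C)[nH]1`: 11%

Of these two, compound 2 holds the lower number. Compound 1 lies above it by a gap well beyond the usual scatter of repeated measurements. The two compounds differ in more than one place, so their gap cannot be pinned on any single structural feature, and it offers no direct guide to the next change.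

That change leads to compound 3 `CC(=O)c1nc([C@@H](O)[C@H](O)[C@H](O)CO)c(-c2ccccc2)[nH]1`, which carries phenyl in place of methyl on an aromatic carbon. The rest of compound 2 stays the same. Among the measured compounds shown here, no measured pair here shows what such a swap does in this assay, so any forecast is loose. Compound 2, at 11%, has little room left to fall, so a small upward move is the more likely outcome, and it may stay within the scatter. The expected step is a number 9 percentage points higher from compound 2 to compound 3 (within the scatter). For compound 3 the estimated value is 20%, with an expected range from 5% to 45%.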

Compound 3, oral bioavailability: 49.6%
Beside the measured number, compound 3's estimate is 29.6 percentage points below it, and the stated range ends below it.
By their numbers in this assay, from the lowest: compound 2; then compound 3; then compound 1.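

In this assay, putting phenyl in place of methyl on this aromatic carbon gives a number 38.6 percentage points higher from compound 2 to compound 3 (beyond the scatter). Compound 2 and compound 3 differ in this one place only, so, unlike the gap between compound 1 and compound 2, this large step can be assigned to a single structural change, and it shows that the group on this carbon of the five-membered ring can strongly affect how much of an oral dose reaches the circulation. The data offer no measured explanation for why the swap has this effect.

One swap at one position cannot separate the effect of the aromatic ring itself from that of the added carbons, and a cyclohexyl ring or a longer alkyl chain on the same carbon would help to tell these two readings apart. Also open is whether a phenyl ring bearing a methoxy group or an amine would move the number further in either direction, since phenyl is the only ring shown at this position.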